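The compounds below may be only part of what the source reports. "The series", "measured", "known", "first", "only" and "open" are said of these compounds alone.

Compound 2, `CCCCCCCCCCCCC(C)OC(=O)NC(=O)Nc1c(C(C)C)cccc1C(C)C`, is the strongest inhibitor among the three compounds measured in an assay on microsomes from intestine for inhibition of acyl-CoA:cholesterol acyltransferase (Oryctolagus cuniculus) (on this read-out higher numbers stand for weaker inhibition and lower numbers for stronger inhibition), where compound 2 gives 46 nM. Its neighbours share the same core and differ only in the chain on the carbamate side. Compound 1, `CCCCCCCCC(C)OC(=O)NC(=O)Nc1c(C(C)C)cccc1C(C)C`, gives 750 nM in this assay, and compound 3, `CCCCCCCCCCCCCCC(C)OC(=O)NC(=O)Nc1c(C(C)C)cccc1C(C)C`, gives 6800 nM. The steps between them are all beyond the scatter: a 16-fold lower number from compound 1 to compound 2 (1.21 log units; beyond the scatter), a 150-fold higher number from compound 2 to compound 3 (2.17 log units; beyond the scatter) and a 9.1-fold higher number from compound 1 to compound 3 (0.96 log units; beyond the scatter). Compound 4, `CCCCCCCCCCCCC(C)(C)OC(=O)NC(=O)Nc1c(C(C)C)cccc1C(C)C`, differs from compound 2 by methyl in place of hydrogen on a saturated chain carbon bound to an oxygen next to a carbonyl group and two saturated chain carbons. Going by the values given here, no measured step touches this carbon; the three measured steps all alter the chain far from the oxygen, so they bear on the change only in showing that the addition of a few carbons anywhere in this chain has moved the read-out by large amounts in either direction. On that footing a shift beyond the scatter is expected for compound 4, its direction uncertain, with a weakening judged somewhat more likely because a 150-fold higher number from compound 2 to compound 3 (2.17 log units; beyond the scatter) shows that added carbon on compound 2 lowered activity sharply. The step from compound 2 to compound 4 is therefore estimated at a 2.8-fold higher number from compound 2 to compound 4 (0.45 log units; beyond the scatter). Compound 4 is expected to give about 130 nM in this assay, within a range from 20 nM to 900 nM.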

Compound 4, half-maximal inhibitory concentration: 65 nM
Compound 4: middle estimate off by 2.0-fold (0.30 log units), on the high side, within the range that was stated.
By their numbers in this assay, from the lowest: compounds 2 and 4 (each within the scatter of the next); then compound 1; then compound 3.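

In this assay, methyl in place of hydrogen on a saturated chain carbon bound to an oxygen next to a carbonyl group and two saturated chain carbons gives a 1.4-fold higher number from compound 2 to compound 4 (0.15 log units; within the scatter), so on this read-out compound 2 and compound 4 cannot be told apart, and this carbon accepts the added methyl. The earlier steps shown here all altered the chain further from the oxygen and all lay beyond the scatter, as with a 150-fold higher number from compound 2 to compound 3 (2.17 log units; beyond the scatter), whereas this first change at the carbon bound to the oxygen lies within it, so adding a carbon to this chain does not always move the number. No evidence is available on what lies behind this result.

The compounds shown do not tell whether ethyl or a longer chain on this same carbon would be accepted as methyl is, or whether an amine or a carboxylic acid there would be. They also leave open whether methyl on this carbon would give the same result with the shorter chain of compound 1 or the longer chain of compound 3.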